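From 4-(difluoromethyl)phenyl to 5-chloropyridin-2-yl on an amide-type nitrogen

A few compounds are considered here, and "the series" means these few. Any claim that something is new, unique, unknown or untested is made for them only; others in the source may bear on it.

Within the data shown here, in an ADME assay on microsomes from liver (Homo sapiens) for metabolic stability (on this read-out higher numbers stand for fast clearance and lower numbers for slow clearance), compound 1 `O=C(Nc1ccc(Cl)cc1F)C(=O)N1CCC(c2ccnc3ccc(F)cc23)CC1` gives 10 mL.min-1.g-1 and compound 2 `O=C(Nc1ccc(C(F)F)cc1)C(=O)N1CCC(c2ccnc3ccc(F)cc23)CC1` gives 17 mL.min-1.g-1, so compound 2 stands within the scatter of the only other measured number. Compound 3 `O=C(Nc1ccc(Cl)cn1)C(=O)N1CCC(c2ccnc3ccc(F)cc23)CC1` carries 5-chloropyridin-2-yl in place of 4-(difluoromethyl)phenyl on an amide-type nitrogen. Among the measured compounds shown here, one measured step bears on this place, a 1.7-fold higher number from compound 1 to compound 2 (0.23 log units; within the scatter), and it stays within the scatter. With that single guide, the expected change is a 1.4-fold lower number from compound 2 to compound 3 (0.15 log units; within the scatter), which means no step beyond the scatter. In this assay, compound 3 is estimated at 12 mL.min-1.g-1, with an expected range of 6 mL.min-1.g-1 to 24 mL.min-1.g-1.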

Compound 3, intrinsic clearance in microsomes: 23 mL.min-1.g-1
Estimate against measurement, compound 3: 1.9-fold (0.28 log units) below; low and high end bracket the measured number.
By their numbers in this assay, from the lowest: compounds 1, 2 and 3 (each within the scatter of the next, the first and the last beyond it).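

In this assay, the step of a 1.4-fold higher number from compound 2 to compound 3 (0.13 log units; within the scatter) shows that a ring with one hetero atom can take this place on the amide-type nitrogen and stay level with 4-(difluoromethyl)phenyl. The step of a 2.3-fold higher number from compound 1 to compound 3 (0.36 log units; beyond the scatter) is the only one at this place that goes beyond the scatter, and it is modest. Nothing shown accounts for either step. The compounds shown leave open how pyrimidin-2-yl or a saturated ring such as cyclohexyl would read on this nitrogen. They also leave open whether a methoxy group or a nitrile in place of the chlorine on the 5-chloropyridin-2-yl ring would shift the number.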